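The compounds below may be only part of what the source reports. "The series", "measured", "known", "first", "only" and "open" are said of these compounds alone.

Of the compounds shown here, three built on one shared core have been measured in an assay on aorta for inhibition of acyl-CoA:cholesterol acyltransferase (Oryctolagus cuniculus); on this read-out lower numbers stand for stronger inhibition and higher numbers for weaker inhibition. Compound 1 `CCCCCNC(=O)Nc1c(OCCCn2cnc(-c3ccccc3)c2)cccc1N(C)C` gives 160 nM. Compound 2 `CN(C)c1cccc(OCCCn2cnc(-c3ccccc3)c2)c1NC(=O)NC1CCCCC1` gives 1070 nM, and the step of a 6.7-fold higher number from compound 1 to compound 2 (0.83 log units; beyond the scatter) is the only one among these three that lies beyond the scatter. Compound 3 `CCCCCNC(=O)Nc1c(OCCCn2ncc(-c3ccccc3)n2)cccc1N(C)C` gives 180 nM and stands second highest of the three numbers, with compound 1 nearest and compound 2 furthest. Compound 4 `CCCCCNC(=O)Nc1c(OCCCn2nnc(-c3ccccc3)n2)cccc1N(C)C` has not yet been measured; it differs from compound 3 by a group of 11 heavy atoms (7 carbon, 4 nitrogen; one five-membered aromatic ring with 4 hetero atoms, one six-membered aromatic ring of carbon only) in place of a group of 11 heavy atoms (8 carbon, 3 nitrogen; one five-membered aromatic ring with 3 hetero atoms, one six-membered aromatic ring of carbon only), on a saturated chain carbon, three bonds along the chain from an oxygen on an aromatic ring. The measured step that bears on this is the earlier exchange at the same place, where a 1.1-fold higher number from compound 1 to compound 3 (0.05 log units; within the scatter) stayed within the scatter, while the exchange of pentyl for cyclohexyl concerns another part of the molecule and says nothing about this one. In this assay the expected step is therefore a 1.2-fold higher number from compound 3 to compound 4 (0.09 log units; within the scatter), no more than the scatter, leaning only slightly toward a higher number. Compound 4 is thus estimated at about 220 nM, within a range from 90 nM to 550 nM.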

Compound 4, half-maximal inhibitory concentration: 230 nM
Estimate against measurement, compound 4: 1.0-fold (0.02 log units) below; low and high end bracket the measured number.
By their numbers in this assay, from the lowest: compounds 1, 3 and 4 (each within the scatter of the next); then compound 2.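

In this assay, replacing the group of compound 3 with 5-phenyl-2H-tetrazol-2-yl on the saturated chain carbon gives a 1.3-fold higher number from compound 3 to compound 4 (0.11 log units; within the scatter), a second exchange at this place that stays within the scatter. The larger exchange of 4-phenyl-1H-imidazol-1-yl for 5-phenyl-2H-tetrazol-2-yl, a 1.4-fold higher number from compound 1 to compound 4 (0.16 log units; within the scatter), also stays within the scatter, so the assay cannot tell compound 1, compound 3 and compound 4 apart, although the nitrogen count of their five-membered aromatic rings differs. Nothing available explains why these rings read alike.

On these data alone, it remains open whether this tolerance would survive a pyridine in place of the phenyl ring or a longer chain between the oxygen and the five-membered ring. As far as these compounds go, it is also open whether the 5-phenyl-2H-tetrazol-2-yl group would behave the same way with cyclohexyl in place of pentyl.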